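Pyrrolidinone series: chloro for dimethylamino on the ring carbon

A few compounds are considered here, and "the series" means these few. Any claim that something is new, unique, unknown or untested is made for them only; others in the source may bear on it.

Compound 1 `CC[C@H]1C[C@@H](c2c(OC)cccc2OC)N(Cc2ccc(OC(F)(F)F)cc2)C1=O` gives 3610 nM in a functional assay on CHO cells for antagonist activity at Orexin receptor type 2 (Homo sapiens), read by FLIPR and calcium flux; a lower number here means a stronger inhibitor, a higher number a weaker inhibitor. Within the data shown here, compound 2 `COc1cccc(OC)c1[C@@H]1C[C@H](N(C)C)C(=O)N1Cc1ccc(OC(F)(F)F)cc1` gives 8300 nM in this assay, the higher of the two numbers; the step of a 2.3-fold higher number from compound 1 to compound 2 (0.36 log units; beyond the scatter) is the only measured step. Compound 3 `COc1cccc(OC)c1[C@@H]1C[C@H](Cl)C(=O)N1Cc1ccc(OC(F)(F)F)cc1` carries the change (chloro in place of dimethylamino on a saturated ring carbon). Among the measured compounds shown here, no measured step covers a chloro at that position, so the expectation leans on compound 2 with 8300 nM and the modest spread to compound 1. For compound 3 in this assay the estimate is 5000 nM, range 1500 nM to 15000 nM, expected as a step of a 1.7-fold lower number from compound 2 to compound 3 (0.22 log units; within the scatter) toward compound 1.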

Compound 3, half-maximal inhibitory concentration: 41 nM
The estimate for compound 3 lay 120-fold (2.09 log units) above the measured number; measured number outside the range, below it.
By their numbers in this assay, from the lowest: compound 3; then compound 1; then compound 2.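

In this assay, this ring carbon proves far more sensitive to its substituent than the earlier pair showed: chloro replacing dimethylamino gives a 200-fold lower number from compound 2 to compound 3 (2.31 log units; beyond the scatter), and chloro replacing ethyl gives an 88-fold lower number from compound 1 to compound 3 (1.94 log units; beyond the scatter). Ethyl and dimethylamino alone had given only a 2.3-fold higher number from compound 1 to compound 2 (0.36 log units; beyond the scatter), so that modest spread did not reveal the range available at this position. No supporting data bear on why chloro differs so sharply from both groups. As far as these compounds go, whether the gain is particular to chloro remains open; bromo, fluoro, methyl or hydroxyl on the same carbon would test this.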